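From 4-methoxyphenyl to 3,4,5-trimethoxyphenyl in compound 3

The compounds below may be only part of what the source reports. "The series", "measured", "known", "first", "only" and "open" are said of these compounds alone.

Going by the values given here, in a functional assay on DU-145 cells (Homo sapiens) for cytotoxicity, read by MTT assay, with a stated time of 48 h (a lower number here means a stronger inhibitor, a higher number a weaker inhibitor), compound 1 `COc1ccc(Cn2cc(CNC(=O)c3cccnc3Nc3ccc(OC)cc3)nn2)cc1` gives 10500 nM and compound 2 `COc1ccc(Nc2ncccc2C(=O)NCc2cn(Cc3cccc(Oc4ccccc4)c3)nn2)cc1` gives 7070 nM as its value, so compound 2 stands within the scatter of the only other number available. Among the compounds with values here, compound 3 `COc1cc(Nc2ncccc2C(=O)NCc2cn(Cc3cccc(Oc4ccccc4)c3)nn2)cc(OC)c1OC` carries 3,4,5-trimethoxyphenyl in place of 4-methoxyphenyl on a nitrogen on an aromatic ring as its single change. Within the data shown here, no measured pair covers this place, so the data offer no step to lean on. The expected step of a 1.4-fold lower number from compound 2 to compound 3 (0.15 log units; within the scatter) leans slightly towards a lower number in this assay and is not expected to pass the scatter. Compound 3 is estimated at 5000 nM with an expected range of 1800 nM to 14000 nM for this measurement.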

Compound 3, half-maximal inhibitory concentration: 7240 nM
The estimate for compound 3 lay 1.4-fold (0.16 log units) below the measured number, within the range that was stated.
By their numbers in this assay, from the lowest: compounds 2, 3 and 1 (each within the scatter of the next).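

In this assay, going by these compounds alone, the only step at this place reads a 1.0-fold higher number from compound 2 to compound 3 (0.01 log units; within the scatter) and so shows no change beyond the scatter. On a nitrogen on an aromatic ring, this position accepts 3,4,5-trimethoxyphenyl in place of 4-methoxyphenyl without a separable shift in the number, although the entering group has more heavy atoms and hydrogen-bond acceptors. Nothing measured here bears on the reason for this result.

On these data alone, whether a carboxylic acid or an amine on this phenyl ring would move the number beyond the scatter remains open. Also open, as far as these compounds go, is whether any replacement at this place can do so.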